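The source may report more compounds than this note shows. Statements on the series, on what has been measured and on what is new or still open speak of the compounds shown alone.

In a functional assay on HT-29 cells (Homo sapiens) for cytotoxicity, read by XTT assay, with a stated time of 72 h (a lower number here means a stronger inhibitor, a higher number a weaker inhibitor), compound 1 `C=C1CC[C@H]2C(C)(C)CCC[C@]2(C)[C@H]1CC/C(C)=C/COc1cc(O)c2c(=O)c(OC/C=C(\C)CC[C@H]3C(=C)CC[C@H]4C(C)(C)CCC[C@]34C)c(-c3ccc(OC)cc3)oc2c1` gives > 100000 nM, a limit of the assay and not a number. Compound 3 `C=C1CC[C@H]2C(C)(C)CCC[C@]2(C)[C@H]1CC/C(C)=C/Cc1c(O)cc(O)c2c(=O)c(O)c(-c3ccc(OC)cc3)oc12` gives > 100000 nM, which is also a limit. For the measured compounds named here, compound 2 `C=C1CC[C@H]2C(C)(C)CCC[C@]2(C)[C@H]1CC/C(C)=C/COc1c(-c2ccc(O)cc2)oc2cc(O)cc(O)c2c1=O` gives the only true number, 30000 nM. Compound 1 therefore stands at the limit of > 100000 nM in this assay, at which 2 of the 3 values shown sit, with no measured potency to build on.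

Compound 4 `C=C1CC[C@H]2C(C)(C)CCC[C@]2(C)[C@H]1CC/C(C)=C/COc1cc(O)c2c(=O)c(OC/C=C(\C)CC[C@H]3C(=C)CC[C@H]4C(C)(C)CCC[C@]34C)c(-c3ccc(O)cc3)oc2c1` makes one change to compound 1: hydrogen in place of methyl on an oxygen on an aromatic ring. Hydrogen takes the place of methyl on an oxygen on an aromatic ring, so 4-methoxyphenyl becomes 4-hydroxyphenyl. Compound 1 and compound 3 both carry 4-methoxyphenyl and neither gives a true number. Going by the values given here, the one compound with 4-hydroxyphenyl, compound 2, gives 30000 nM. This is a weak hint, as it rests on a single compound, but it points towards a modest gain in strength in this assay. The expected change, an at least 1.4-fold lower number from compound 1 to compound 4 (0.15 log units; that floor lies within the scatter), may well stay hidden if the result again reaches the limit. Compound 4 is estimated at 70000 nM, with an expected range of 25000 nM to 150000 nM.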

Compound 4, half-maximal inhibitory concentration: > 100000 nM
Compound 4 was reported as a limit; the forecaster's own chance of this, stated with the estimate: 50%; middle value at least 1.4-fold (0.15 log units) away from the limit.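

Compound 1 and compound 4 both end at a limit of the assay and not at a number, so the change from 4-methoxyphenyl to 4-hydroxyphenyl gives no step that can be read: the limit of > 100000 nM in this assay, at which 3 of the 4 values shown sit.

The compounds shown leave open whether this change alters strength at all in this assay.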